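Moving the ring nitrogen in the amide partner

The source may hold more compounds than are shown below. What is called first, only, known or untested is meant among the compounds shown, and "the series" means these compounds.

Three compounds sharing one core have been measured in a functional assay on the whole organism (strain Wistar) for inhibition, with Rattus norvegicus as the target, read by paw edema, with a stated time of 3 h, at a dose of 100 mg/kg; a lower number here means less inhibition, a higher number more inhibition at the dose given (going by the name of the read-out):

compound 1, `COc1cc2c(cc1OC)C(CC(=O)Nc1ccccc1)CC2`, 36.2%
compound 2, `COc1cc2c(cc1OC)C(CC(=O)Nc1cccc(Cl)c1)CC2`, 24.6%
compound 3, `COc1cc2c(cc1OC)C(CC(=O)Nc1cccnc1)CC2`, 33.3%

Compound 3 stands second highest of the three numbers. Its nearest neighbour is compound 1, and the step of a number 2.9 percentage points lower from compound 1 to compound 3 (within the scatter) is within the scatter. The furthest is compound 2, and the step of a number 8.7 percentage points higher from compound 2 to compound 3 (within the scatter) is also within the scatter. Among the measured compounds shown here, the only step that reaches beyond the scatter is a number 11.6 percentage points lower from compound 1 to compound 2 (beyond the scatter), and it involves a chloro group rather than a ring nitrogen.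

Compound 4, `COc1cc2c(cc1OC)C(CC(=O)Nc1ccncc1)CC2`, has not yet been measured. It differs from compound 3 by pyridin-4-yl in place of pyridin-3-yl on an amide-type nitrogen. For the measured compounds named here, the steps that bear on this change are those that already swap the group on the amide-type nitrogen, a number 2.9 percentage points lower from compound 1 to compound 3 (within the scatter) and a number 8.7 percentage points higher from compound 2 to compound 3 (within the scatter), and both are within the scatter. Replacing phenyl by pyridin-3-yl did not move the number beyond the scatter, so moving the nitrogen within the pyridyl ring is expected to give no step beyond the scatter either: the expected step is a number 1.3 percentage points lower from compound 3 to compound 4 (within the scatter).

Compound 4 is therefore estimated at 32%, in a range from 20% to 43%.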

Compound 4, a percentage reported as inhibition, in the whole organism at one dose (the size of the read-out at that dose, not a potency): 42%
Beside the measured number, compound 4's estimate is 10 percentage points below it; the range from low to high includes it.
By their numbers in this assay, from the lowest: compounds 2, 3, 1 and 4 (each within the scatter of the next, the first and the last beyond it).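

In this assay, exchanging pyridin-3-yl for pyridin-4-yl on the amide-type nitrogen, two groups with the same atoms joined differently, gives a number 8.7 percentage points higher from compound 3 to compound 4 (within the scatter) and so does not separate the two pyridyl compounds, while the swap from phenyl gives a number 5.8 percentage points higher from compound 1 to compound 4 (within the scatter) and does not separate those two either. What is new is that a swap at this position now clears the scatter when the starting group is 3-chlorophenyl: pyridin-4-yl gives a number 17.4 percentage points higher from compound 2 to compound 4 (beyond the scatter) whereas pyridin-3-yl gave a number 8.7 percentage points higher from compound 2 to compound 3 (within the scatter) and did not. The data shown offer no measurement that would account for this difference.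

The compounds shown leave open whether pyridin-2-yl on the amide-type nitrogen would sit with the two pyridyl compounds, and whether a methoxy or an amino group on the phenyl ring would give a step like that of the chloro group. Also open, on these data alone, is whether the separation between compound 2 and compound 4 would persist at another dose or at another time after dosing.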